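Oxan-4-ylmethyl amide in a thiazolopiperidine series

The source may report more compounds than this note shows. Statements on the series, on what has been measured and on what is new or still open speak of the compounds shown alone.

Compound 1 `CC(=O)N1CCc2nc(C#Cc3ccccc3)sc2C1` in an assay on HEK293 cells for positive allosteric modulation of metabotropic glutamate receptor 5 (Homo sapiens), read by FLIPR, with a stated time of 1 h (a higher number here means that more compound is needed for the effect, a lower number that less compound is needed), reaches only the limit > 10000 nM, which is a limit of the measurement and not a number (the limit of > 10000 nM in this assay, at which 1 of the 3 values shown sits).
Compound 2 `COC1CC(C(=O)N2CCc3nc(C#Cc4ccccc4)sc3C2)C1` gives 640 nM.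
Compound 3 `CC1CCC(C(=O)N2CCc3nc(C#Cc4ccccc4)sc3C2)CC1` gives 190 nM.

Among the numbers shown, compound 3 stands lowest, with compound 2 nearest a 3.4-fold lower number from compound 2 to compound 3 (0.53 log units; beyond the scatter). Compound 4 `O=C(CC1CCOCC1)N1CCc2nc(C#Cc3ccccc3)sc2C1` differs from compound 3 by (oxan-4-yl)methyl in place of 4-methylcyclohexyl on a carbonyl carbon. Within the data shown here, the steps that bear on it are an at least 52-fold lower number from compound 1 to compound 3 (1.72 log units; beyond the scatter), which shows the weight of a ring at this carbonyl, and a 3.4-fold lower number from compound 2 to compound 3 (0.53 log units; beyond the scatter), where the oxygen-bearing ring gave the higher number. An oxygen-bearing ring enters again in compound 4, so the number for compound 4 is expected to rise moderately, a 2.6-fold higher number from compound 3 to compound 4 (0.42 log units; beyond the scatter). Compound 4 is therefore estimated at 500 nM, between 150 nM and 2000 nM.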

Compound 4, half-maximal effective concentration: 470 nM
Beside the measured number, compound 4's estimate is 1.1-fold (0.03 log units) above it; the measured number falls inside the stated range.
By their numbers in this assay, from the lowest: compound 3; then compounds 4 and 2 (each within the scatter of the next). At a limit, above all of these: compound 1.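

In this assay, (oxan-4-yl)methyl in place of 4-methylcyclohexyl gives a 2.5-fold higher number from compound 3 to compound 4 (0.39 log units; beyond the scatter), so a ring with a hetero atom again lies on the higher side of compound 3, now with the heavy-atom count unchanged. The two oxygen-bearing groups cannot be told apart, with a 1.4-fold lower number from compound 2 to compound 4 (0.13 log units; within the scatter). Compound 1 stands at a limit, which makes an at least 21-fold lower number from compound 1 to compound 4 (1.32 log units; beyond the scatter) only a bound: the limit of > 10000 nM in this assay, at which 1 of the 4 values shown sits.

As far as these compounds go, what cyclohexylmethyl on this carbonyl carbon would give stays open, so the shares of the ring oxygen and the added chain carbon in the step from compound 3 cannot be separated. From the compounds shown here alone, an amine in that ring, as in piperidin-4-ylmethyl, is equally open.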